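This account rests on a few compounds, and the source may have more. Where it says the series, first, only, none or still open, it means among the compounds named here.

Measured so far in a functional assay on CHO cells for activation of 5-hydroxytryptamine receptor 1D (Homo sapiens), read by GTPgammaS binding; a lower number here means that less compound is needed, a higher number that more compound is needed for the effect:
- compound 1 `NC(=O)C(c1ccccc1)N1CCN(CCCc2c[nH]c3ccc(-n4cnnc4)cc23)CC1` gives 0.2 nM
- compound 2 `c1cnc(N2CCN(CCCc3c[nH]c4ccc(-n5cnnc5)cc34)CC2)nc1` gives 0.6 nM

Compound 2 stands at the higher of the two numbers: the step of a 3.0-fold higher number from compound 1 to compound 2 (0.48 log units; beyond the scatter) is the only one measured, so a pyrimidin-2-yl group on the ring nitrogen costs a little relative to the carbamoyl(phenyl)methyl group of compound 1.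

Compound 3 `c1ccc(CCCN2CCN(CCCc3c[nH]c4ccc(-n5cnnc5)cc34)CC2)cc1` is not yet measured. It differs from compound 2 in one place: 3-phenylpropyl in place of pyrimidin-2-yl on an amine nitrogen in a ring. For the measured compounds named here, no measured step swaps these two exact groups, but the step from compound 1 to compound 2 shows that the ring nitrogen accepts quite different substituents while both compounds stay in the same narrow low range. A 3-phenylpropyl group returns a phenyl ring to that position, as in compound 1. The expected step is therefore small, a 1.5-fold lower number from compound 2 to compound 3 (0.18 log units; within the scatter), going slightly downward rather than up. Compound 3 is estimated at 0.4 nM, with a range from 0.1 nM to 2 nM.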

Compound 3, half-maximal effective concentration: 4 nM
Beside the measured number, compound 3's estimate is 10-fold (1.00 log units) below it; measured number outside the range, above it.
By their numbers in this assay, from the lowest: compound 1; then compound 2; then compound 3.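

In this assay, for the compounds shown here, the ring nitrogen proves less tolerant than the first two compounds suggested: 3-phenylpropyl in place of pyrimidin-2-yl gives a 6.7-fold higher number from compound 2 to compound 3 (0.82 log units; beyond the scatter) and, in place of carbamoyl(phenyl)methyl, gives a 20-fold higher number from compound 1 to compound 3 (1.30 log units; beyond the scatter) as the largest step so far. A phenyl ring at this position therefore does not by itself keep the number low, since compound 1 and compound 3 both carry one and yet lie furthest apart. Nothing available explains this rise.

The compounds shown leave open whether the higher number goes with the propyl chain or with the ring of carbon only. A benzyl group on the same nitrogen, or a pyrimidin-2-yl group carried on a propyl chain, would help separate these two possibilities.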